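The compounds below may be only part of what the source reports. "The series", "measured", "known", "first", "only" and "open" are said of these compounds alone.

In a functional assay on KB cells (Homo sapiens) for cytotoxicity (on this read-out higher numbers stand for an effect only at larger amounts of compound and lower numbers for an effect already at smaller amounts), compound 1 (`COC1=C(C)C(=O)/C(=C(O)/C=C/c2cccc3ccccc23)C(=O)C1(C)C`) gives 1.3 ug/mL, compound 2 (`COC1=C(C)C(=O)/C(=C(O)/C=C/c2ccco2)C(=O)C1(C)C`) gives 8.8 ug/mL and compound 3 (`COC1=CC(O)=C(C(=O)/C=C/c2ccccc2)C(=O)C1(C)C`) gives 2.9 ug/mL. Compound 3 therefore holds the middle of the three numbers, nearer to compound 1 than to compound 2, with both gaps beyond the scatter. Compound 4 (`CCC1=C(OC)C(C)(C)C(=O)C(C(=O)/C=C/c2ccccc2)=C1O`) departs from compound 3 in one place: ethyl in place of hydrogen on a double-bonded ring carbon. Among the measured compounds shown here, no measured pair isolates this change, and compound 1 and compound 2 each differ from compound 3 in more than one place. The expectation therefore rests only on the narrow spread of the series, from compound 1 at 1.3 ug/mL to compound 2 at 8.8 ug/mL. In this assay, no step beyond the scatter is expected, with a slight lean towards a lower number. The estimated move is a 1.2-fold lower number from compound 3 to compound 4 (0.06 log units; within the scatter). For compound 4 the estimated value is 2.5 ug/mL, with an expected range from 1 ug/mL to 6.5 ug/mL.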

Compound 4, concentration for half-maximal effect: 0.3 ug/mL
The estimate for compound 4 lay 8.3-fold (0.92 log units) above the measured number; the whole stated range lies above it.
By their numbers in this assay, from the lowest: compound 4; then compound 1; then compound 3; then compound 2.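

In this assay, ethyl in place of hydrogen on a double-bonded ring carbon gives a 9.7-fold lower number from compound 3 to compound 4 (0.99 log units; beyond the scatter), so a substituent at this position can move the read-out well beyond the scatter, towards an effect at smaller amounts of compound. Among the compounds shown here, the earlier compounds offered no pair isolating this position, so this single pair is its only direct reading. Nothing available bears on why the step is this large.

Still open, from the compounds shown here alone, is whether the step is specific to ethyl or would also appear with a methyl group, a longer chain such as propyl, or an amine at the same carbon. For the compounds shown here, also open is whether the step holds when other parts of the shared core change, since only one pair isolates it.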